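The source may hold more compounds than are shown below. What is called first, only, known or untested is meant among the compounds shown, and "the series" means these compounds.

Measured in an ADME assay on Karpas-1106P cells (Homo sapiens) for cytotoxicity; a lower number here means that less compound is needed, a higher number that more compound is needed for the effect:

- Compound 1 `Cc1ccc(S(=O)(=O)N[C@@H](CC(=O)NC(C)(C)C)C(=O)NCCNC(=O)Nc2ccccc2)cc1`: > 11100 nM, a limit.
- Compound 2 `Cc1ccc(S(=O)(=O)N[C@@H](CC(=O)NC(C)(C)C)C(=O)NCCNC(=O)c2cccc(C(C)C)c2)cc1`: > 11100 nM, a limit.
- Compound 3 `Cc1ccc(S(=O)(=O)N[C@@H](CC(=O)NC(C)(C)C)C(=O)NCCNC(=O)c2ccccc2F)cc1`: > 11100 nM, a limit.

Compound 1 has no numerical value, only a limit. The other two compounds offer no number to set it against, and the whole set sits at one ceiling: the limit of > 11100 nM in this assay, at which 3 of the 3 values shown sit.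

Compound 4 `Cc1ccc(S(=O)(=O)N[C@@H](CC(=O)NC(C)(C)C)C(=O)NCCNC(=O)c2ccc(F)cc2)cc1` has not yet been measured. Its change from compound 1 is 4-fluorophenyl in place of anilino on a carbonyl carbon.

For the measured compounds named here, three measured steps bear on this change. The first swaps anilino for another aryl group at the same place and is a step that the two limits leave unreadable from compound 1 to compound 3. The second is the same kind of swap and is a step that the two limits leave unreadable from compound 1 to compound 2. The third, a step that the two limits leave unreadable from compound 2 to compound 3, exchanges the two incoming groups. None of the three has a readable size, so they give no direction for this assay. They show only that the anilino replacements in compound 2 and compound 3 did not bring a value under the ceiling. The same outcome is expected here, with no readable step in either direction. The expected step is a step that the limit leaves unreadable from compound 1 to compound 4. A limit is the most likely report for compound 4.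

For compound 4 the estimated value is 15000 nM, with an expected range of 7000 nM to 30000 nM.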

Compound 4, half-maximal effective concentration: > 11100 nM
Compound 4: no number, only a limit; the forecaster's own chance of this, stated with the estimate: 85%; the middle value lies beyond the limit too.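

In this assay compound 4 gives > 11100 nM, a limit. No new step can be read from compound 4 to compound 1, compound 2 or compound 3, as all four carry only limits: the limit of > 11100 nM in this assay, at which 4 of the 4 values shown sit.

The compounds shown leave open where any of the four truly lies and whether changing the group on this carbonyl carbon shifts the value at all.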